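The source may hold more compounds than are shown below. What is called first, only, known or untested is meant among the compounds shown, and "the series" means these compounds.

Compound 1 `CC(C)(C)n1ncc(OCc2nnc(-c3ccccc3Cl)o2)c(Cl)c1=O` is the stronger of the two compounds that gave a number in a functional assay on the whole organism for inhibition, with Mythimna separata as the target, with a stated time of 5 days (a lower number here means that less compound is needed, a higher number that more compound is needed for the effect), where compound 1 gives 61.2 ug/mL. Compound 3 `CCCCn1ncc(OCc2nnc(-c3ccc(F)cc3)o2)c(Cl)c1=O` gives 162 ug/mL in this assay, a step beyond the usual scatter. For compound 2 `CCCCn1ncc(OCc2nnc(-c3ccccc3)o2)c(Cl)c1=O` this assay reports only a limit, > 300 ug/mL. Within the data shown here, the one measured step, an at least 1.8-fold lower number from compound 2 to compound 3 (0.26 log units; that floor lies within the scatter), comes from a fluoro in place of hydrogen on an aromatic carbon. Compound 4 `CC(C)(C)n1ncc(OCc2nnc(-c3c(F)cccc3F)o2)c(Cl)c1=O` differs from compound 1 by 2,6-difluorophenyl in place of 2-chlorophenyl on an aromatic carbon. Among the measured compounds shown here, no measured step covers this change directly, and the one fluorine step is small, so compound 4 is expected to stay close to compound 1, a 1.1-fold higher number from compound 1 to compound 4 (0.03 log units; within the scatter). Compound 4 is therefore estimated at 65 ug/mL, between 25 ug/mL and 170 ug/mL.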

Compound 4, half-maximal effective concentration: 45.4 ug/mL
Compound 4: the middle estimate sits 1.4-fold (0.16 log units) above what was measured; low and high end bracket the measured number.
By their numbers in this assay, from the lowest: compounds 4 and 1 (each within the scatter of the next); then compound 3. At a limit, above all of these: compound 2.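

Putting 2,6-difluorophenyl in place of 2-chlorophenyl on the shared core gives a 1.3-fold lower number from compound 1 to compound 4 (0.13 log units; within the scatter) in this assay, so this exchange leaves no readable change at this position. This is the first step shown on this aromatic group between two compounds that both give a number rather than a limit. Nothing measured here offers a reason for this result. From the compounds shown here alone, whether an amine or a carboxylic acid on this phenyl ring would keep a similar number stays open. So does whether this exchange would give a similar step with the different chain of compound 3.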